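This account rests on a few compounds, and the source may have more. Where it says the series, first, only, none or still open, it means among the compounds named here.

Compound 2 `COc1ccc(Cn2ccc3cc(/C(C)=C/C(=O)Nc4ccccc4OCCCC(=O)O)ccc32)cc1` gives 480 nM in an assay on Prostate gland for inhibition of steroid 5-alpha-reductase (Rattus norvegicus) (on this read-out lower numbers stand for stronger inhibition and higher numbers for weaker inhibition), the highest of the two numbers recorded; compound 1 `CCCCC(CC)n1ccc2cc(/C(C)=C/C(=O)Nc3ccccc3OCCCC(=O)O)ccc21` gives 7.1 nM. Among the measured compounds shown here, the one step seen, a 68-fold higher number from compound 1 to compound 2 (1.83 log units; beyond the scatter), is large. Compound 3 `CCCC(c1ccccc1)n1ccc2cc(/C(C)=C/C(=O)Nc3ccccc3OCCCC(=O)O)ccc21` differs from compound 2 by 1-phenylbutyl in place of 4-methoxybenzyl on an aromatic nitrogen. For the measured compounds named here, the entering group is branched at the carbon attached to the ring nitrogen, as in compound 1, so a drop in number toward compound 1 is expected, though only a single step informs this. Compound 3 is estimated at 30 nM, between 8 nM and 120 nM, meaning an expected step of a 16-fold lower number from compound 2 to compound 3 (1.20 log units; beyond the scatter).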

Compound 3, half-maximal inhibitory concentration: 9.1 nM
Compound 3: the middle estimate sits 3.3-fold (0.52 log units) above what was measured, within the range that was stated.
By their numbers in this assay, from the lowest: compounds 1 and 3 (each within the scatter of the next); then compound 2.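

In this assay, the change to 1-phenylbutyl on the aromatic nitrogen gives a 53-fold lower number from compound 2 to compound 3 (1.72 log units; beyond the scatter), so a group holding a benzene ring can sit here without the high number of compound 2. Set against 1-ethylpentyl, 1-phenylbutyl gives a 1.3-fold higher number from compound 1 to compound 3 (0.11 log units; within the scatter), and in these compounds the two low numbers both go with branching at the carbon attached to the ring nitrogen. No evidence is available that explains these steps. Still open, on these data alone, is whether the branch or the loss of the methoxy carries the change, which a plain benzyl group on this nitrogen would help to separate.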